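Adding a Methyl Group and Cytotoxicity in Leukaemia Cells

A few compounds are considered here, and "the series" means these few. Any claim that something is new, unique, unknown or untested is made for them only; others in the source may bear on it.

Compound 1, `CSC1N=CNc2c(C)ncn21`, gives 176000 nM in a functional assay on CCRF-CEM cells (Homo sapiens) for cytotoxicity; on this read-out higher numbers stand for lower toxicity in this test and lower numbers for higher toxicity in this test. Compound 2, `CSC1N=CNc2c(C)nc(C)n21`, differs from compound 1 by methyl in place of hydrogen on an aromatic carbon. In this assay compound 2 gives 440000 nM, and the step of a 2.5-fold higher number from compound 1 to compound 2 (0.40 log units; beyond the scatter). Compound 3, `Cc1nc(C)n2c1NC(SCc1ccccc1)NC2=O`, has another core; how its core differs from that of compound 1 is not broken down here. In this assay compound 3 gives 266000 nM. Compound 4, `Cc1ccc(CSC2NC(=O)n3c(C)nc(C)c3N2)cc1`, is not yet measured and differs from compound 3 by methyl in place of hydrogen on an aromatic carbon. This is the same kind of change as from compound 1 to compound 2, but at a different place: on a six-membered aromatic ring of carbon only, para to a large group, rather than on a five-membered aromatic ring with 2 nitrogen, between two ring nitrogen atoms. Because that earlier step was a 2.5-fold higher number from compound 1 to compound 2 (0.40 log units; beyond the scatter), a modest rise is expected for compound 4. The expected step of a 1.5-fold higher number from compound 3 to compound 4 (0.18 log units; within the scatter) rests on that single precedent. Compound 4 is thus estimated at 400000 nM, between 180000 nM and 900000 nM.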

Compound 4, half-maximal cytotoxic concentration: 88800 nM
Compound 4: the middle estimate sits 4.5-fold (0.65 log units) above what was measured; measured number outside the range, below it.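

In this assay, replacing phenyl with 4-methylphenyl gives a 3.0-fold lower number from compound 3 to compound 4 (0.48 log units; beyond the scatter), which here means higher toxicity in this test. The same kind of change therefore does not carry over from one core to another in this series, and its direction reverses: the same change on two cores in this assay, a 2.5-fold higher number (0.40 log units; beyond the scatter) from compound 1 to compound 2 and a 3.0-fold lower number (0.48 log units; beyond the scatter) from compound 3 to compound 4, 7.5-fold (0.87 log units) apart, beyond the scatter of two such steps. This does not show whether the core or the place of the methyl decides the outcome, as the two pairs differ in both and each place rests on a single step.

On these data alone, it remains open whether the methyl would give the same step at one place on both cores. As far as these compounds go, it is also open how a methoxy group, a chlorine atom or an amine would behave on that phenyl ring.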